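A few compounds are considered here, and "the series" means these few. Any claim that something is new, unique, unknown or untested is made for them only; others in the source may bear on it.

Working notes on the series, read in a functional assay (aorta) with Oryctolagus cuniculus as the target; a higher number here means weaker binding, a lower number tighter binding. Compound 1 `COc1cc(C(C)=O)ccc1OCCCN1CCC(C(c2ccc(Cl)cc2)c2ccc(Cl)cc2)CC1` gives 2.51 nM and compound 2 `COC(=O)c1ccc(OCCCN2CCC(C(c3ccc(F)cc3)c3ccc(F)cc3)CC2)c(OC)c1` gives 1.26 nM. Within the data shown here, these two values lie within the usual scatter of each other, so compound 2 stands level with compound 1 on the numbers so far.

Compound 3 `Fc1ccc(OCCCN2CCC(C(c3ccc(F)cc3)c3ccc(F)cc3)CC2)cc1` carries 4-fluorophenyl in place of 2-methoxy-4-(methoxycarbonyl)phenyl on an oxygen on a saturated carbon. Among the measured compounds shown here, no measured pair differs in one place, and no measured compound has 4-fluorophenyl on that oxygen, so the data give no direct size for this change. A modest move towards weaker binding in this assay is expected, though with low confidence. The estimated change is a 4.0-fold higher number from compound 2 to compound 3 (0.60 log units; beyond the scatter). For compound 3 the estimated value is 5 nM, with an expected range of 1.3 nM to 20 nM.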

Compound 3, dissociation constant: 1.26 nM
For compound 3 the middle estimate is 4.0-fold (0.60 log units) above the measured one, outside the stated range (below it).
By their numbers in this assay, from the lowest: compounds 2, 3 and 1 (each within the scatter of the next).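

In this assay, among these compounds, replacing 2-methoxy-4-(methoxycarbonyl)phenyl with 4-fluorophenyl on an oxygen on a saturated carbon gives no change at the digits printed from compound 2 to compound 3 (within the scatter), the first step that differs in one place. This position therefore accepts a smaller group with no hydrogen-bond acceptors, and in this pair neither the methoxy nor the methoxycarbonyl group is needed to hold the number at this level. No available evidence bears on why the two groups read alike.

Still open, as far as these compounds go, is whether this position stays as accepting with a group of another kind on that oxygen, such as a carboxylic acid, an amine or unsubstituted phenyl. The pair also leaves open whether the same replacement reads alike on the core of compound 1, which carries chlorine where compound 2 carries fluorine.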